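From compound 2 to compound 4: exchanging a ring group

The source may hold more compounds than are shown below. What is called first, only, known or untested is meant among the compounds shown, and "the series" means these compounds.

- compound 1 `CCCCNC(=O)C(=O)NCCCC/C=C\CCCCCCC(=O)OCCOCCOCCO`: 1500 nM
- compound 2 `CCCCCNC(=O)NCCCC/C=C\CCCCCS(=O)(=O)c1ncn[nH]1`: 3100 nM
- compound 3 `CCCCCCC(=O)N(CCCC/C=C\CCCCCCc1nnn[nH]1)C(C)C`: 1000 nM

In a functional assay on Coronary artery (Bos taurus) (a higher number here means that more compound is needed for the effect, a lower number that less compound is needed), compound 2 gives 3100 nM. This is the highest of the three numbers, and the other two compounds both lie lower by more than the usual scatter. The next compound to be tested is compound 4 `CCCCCNC(=O)NCCCC/C=C\CCCCCCc1noc(=S)[nH]1`, which keeps most of compound 2 but changes one group: a group of 7 heavy atoms (3 carbon, 2 nitrogen, 1 oxygen, 1 sulfur; one five-membered aromatic ring with 3 hetero atoms) in place of a group of 8 heavy atoms (2 carbon, 3 nitrogen, 2 oxygen, 1 sulfur; one five-membered aromatic ring with 3 hetero atoms), on a saturated chain carbon, five bonds along the chain from a double-bonded chain carbon. The change sits on a saturated chain carbon, five bonds along the chain from a double-bonded chain carbon.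

Going by the values given here, no two measured compounds differ in just one place, so no measured step can serve as a direct guide. A small move to a lower number in this assay seems most likely, since compound 1 shows 1500 nM and compound 3 shows 1000 nM. The expected change is a 1.8-fold lower number from compound 2 to compound 4 (0.26 log units; within the scatter), which would not clearly exceed the usual scatter. For compound 4 the estimated value is 1700 nM, with an expected range from 500 nM to 5500 nM.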

Compound 4, half-maximal effective concentration: 3300 nM
Estimate against measurement, compound 4: 1.9-fold (0.29 log units) below; low and high end bracket the measured number.
By their numbers in this assay, from the lowest: compounds 3 and 1 (each within the scatter of the next); then compounds 2 and 4 (each within the scatter of the next).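

In this assay the exchange gives a 1.1-fold higher number from compound 2 to compound 4 (0.03 log units; within the scatter), a step within the usual scatter, so the two groups cannot be told apart in this assay. At this place, on a saturated chain carbon five bonds along the chain from a double-bonded chain carbon, the group of 8 heavy atoms can therefore give way to the group of 7 heavy atoms with no clear change in the number, although the new group has fewer hydrogen-bond acceptors and fewer double bonds outside aromatic rings. No measurement shown explains why the two groups behave alike.

From the compounds shown here alone, whether a carboxylic acid or a simple amine at this place would also leave the number within the scatter remains open. Going by these compounds alone, compound 1 and compound 3 differ from the others in more than one place, so no steps involving them can be read.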